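An amide swap at the carbonyl carbon

The source may hold more compounds than are shown below. What is called first, only, known or untested is meant among the compounds shown, and "the series" means these compounds.

Compound 2 `COc1cc(-n2cccc2C(=O)N2CCC(C)CC2)ccc1Nc1ncc(Cl)c(Nc2ccccc2NS(C)(=O)=O)n1` gives 2200 nM in a functional assay on A549 cells (Homo sapiens) for antiproliferative activity, read by MTT assay, with a stated time of 72 h; a higher number here means a weaker inhibitor, a lower number a stronger inhibitor. On the numbers shown, compound 2 stands alongside compound 1 `COC(=O)c1cccn1-c1ccc(Nc2ncc(Cl)c(Nc3ccccc3NS(C)(=O)=O)n2)c(OC)c1`, which in this assay gives 2510 nM; the step of a 1.1-fold lower number from compound 1 to compound 2 (0.06 log units; within the scatter) lies within the scatter. Compound 3 `COc1cc(-n2cccc2C(=O)NCCO)ccc1Nc1ncc(Cl)c(Nc2ccccc2NS(C)(=O)=O)n1` differs from compound 2 by (2-hydroxyethyl)amino in place of 4-methylpiperidin-1-yl on a carbonyl carbon. Among the compounds with values here, the one measured step sits at the same carbonyl carbon and was small, so only a step within the scatter is expected in this assay, in no clear direction. Compound 3 is therefore estimated at 2200 nM, between 1000 nM and 5000 nM, corresponding to an expected step of no change at the digits printed from compound 2 to compound 3 (within the scatter).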

Compound 3, half-maximal inhibitory concentration: > 10000 nM
Compound 3 ended at the assay's limit; the forecaster's own chance of this, stated with the estimate: 5%; middle value at least 4.5-fold (0.65 log units) from the limit.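

Replacing 4-methylpiperidin-1-yl with (2-hydroxyethyl)amino on the carbonyl carbon moves the read-out in this assay (an at least 4.5-fold higher number from compound 2 to compound 3 (0.65 log units; beyond the scatter)), and replacing methoxy with the same group does so too (an at least 3.9-fold higher number from compound 1 to compound 3 (0.60 log units; beyond the scatter)). This position is therefore not indifferent to every group, which the methoxy and 4-methylpiperidin-1-yl compounds alone did not show. The result for compound 3 is a limit of the assay and not a number: the limit of > 10000 nM in this assay, at which 1 of the 3 values shown sits.

The compounds shown leave open whether the hydroxyl or the open chain goes with this change. A 2-methoxyethylamino chain, a morpholin-4-yl ring or a carboxylic acid on the same carbonyl carbon would help separate the two.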